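The source may hold more compounds than are shown below. What is called first, only, known or untested is meant among the compounds shown, and "the series" means these compounds.

Compounds measured so far:
compound 1 `O=C1CSC(c2cccc(Cl)c2)N1CCN1CCCCC1` gives 45% in an ADME assay on Vero cells (Chlorocebus sabaeus) for cytotoxicity, read by neutral red uptake, tested at 394 ug/mL; on this read-out higher numbers stand for a weaker effect at the one concentration tested and lower numbers for a stronger effect;
compound 2 `Cc1ccc(C2SCC(=O)N2CCN2CCCCC2)cc1` gives 51%;
compound 3 `O=C1CSC(c2cccc(F)c2)N1CCN1CCCCC1` gives 60%.

Compound 3 holds the highest of the three numbers. Its nearest neighbour is compound 2, which sits within the scatter of it, while compound 1 lies beyond the scatter below it, as the step of a number 15 percentage points higher from compound 1 to compound 3 (beyond the scatter) shows. The two other steps, a number 6 percentage points higher from compound 1 to compound 2 (within the scatter) and a number 9 percentage points higher from compound 2 to compound 3 (within the scatter), both stay within the scatter.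

Compound 4 `O=C1CSC(c2ccccc2Cl)N1CCN1CCCCC1` has not yet been measured. It differs from compound 3 in one place: 2-chlorophenyl in place of 3-fluorophenyl on a saturated ring carbon

The step that bears most directly on this change is a number 15 percentage points higher from compound 1 to compound 3 (beyond the scatter), a modest step beyond the scatter when fluoro gave way to chloro on the aromatic carbon. For the measured compounds named here, compound 4 brings chloro back, though at a different position on the ring, for which no step is known. Because the step of a number 15 percentage points higher from compound 1 to compound 3 (beyond the scatter) went upward on going to fluoro, a step of similar size downward is expected on going to compound 4, with the position change as an unknown.

The step of a number 10 percentage points lower from compound 3 to compound 4 (within the scatter) is therefore expected. Compound 4 is estimated at 50%, in the range from 35% to 65%.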

Compound 4, a percentage reported as activity, at one concentration (the size of the read-out at that concentration, not a potency): 31%
For compound 4 the middle estimate is 19 percentage points above the measured one; the whole stated range lies above it.
By their numbers in this assay, from the lowest: compound 4; then compounds 1, 2 and 3 (each within the scatter of the next, the first and the last beyond it).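

In this assay, for the compounds shown here, the earlier compounds varied the group on the saturated ring carbon without showing whether the place of a halogen on the phenyl ring counts. Compound 4 shows that it does: with chlorine kept and only its place changed, 2-chlorophenyl in place of 3-chlorophenyl gives a number 14 percentage points lower from compound 1 to compound 4 (beyond the scatter). The other two steps, a number 20 percentage points lower from compound 2 to compound 4 (beyond the scatter) and a number 29 percentage points lower from compound 3 to compound 4 (beyond the scatter), show that compound 4 stands beyond the scatter of all three earlier compounds, which makes 2-chlorophenyl the group with the strongest effect at the one concentration tested among these four, and nothing shown here accounts for this.

From the compounds shown here alone, it remains open whether the lower number belongs to chlorine at this place on the phenyl ring or would recur with 2-fluorophenyl or 2-methylphenyl on the same saturated ring carbon. Also open, going by these compounds, is how a phenyl ring carrying an amine or a carboxylic acid would read, and how these compounds would rank across a range of concentrations rather than at a single one.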